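A few compounds are considered here, and "the series" means these few. Any claim that something is new, unique, unknown or untested is made for them only; others in the source may bear on it.

Of the compounds shown here, three of one shared core have been measured in a functional assay on DU-145 cells (Homo sapiens) for inhibition, read by trypan blue exclusion, with a stated time of 96 h; on this read-out lower numbers stand for stronger inhibition of growth and higher numbers for weaker inhibition of growth. Compound 1 `COc1ccc(/C=C(\C(=O)c2ccc(Br)cc2)S(=O)(=O)c2ccc(Br)cc2)c(F)c1` gives 10000 nM. Compound 2 `O=C(/C(=C\c1ccccc1OCc1ccccc1)S(=O)(=O)Cc1ccc(F)cc1)c1ccc(Cl)cc1` gives 10000 nM, the same number at the digits shown as compound 1, so the two sit level and together at the low end of the three numbers. For the measured compounds named here, compound 3 `COc1ccc(/C=C(/Sc2ccc(Br)cc2)C(=O)c2ccc(Br)cc2)c(F)c1` gives 20000 nM, and the single step of a 2.0-fold higher number from compound 1 to compound 3 (0.30 log units; within the scatter) is within the scatter, so nothing separates the three measured compounds beyond repeat-to-repeat variation.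

The untested compound 4 `O=C(/C(=C\c1ccc(Br)c([N+](=O)[O-])c1)S(=O)(=O)c1ccc(Br)cc1)c1ccc(Br)cc1` differs from compound 1 in one place: 4-bromo-3-nitrophenyl in place of 2-fluoro-4-methoxyphenyl on a double-bonded chain carbon bound to a double-bonded chain carbon. Going by the values given here, no measured pair changes this part of the molecule; the one measured step, from compound 1 to compound 3, touches a different position and was itself within the scatter. With all three measured numbers level, there is no basis for expecting either a stronger or a weaker result, so the expectation for compound 4 is a number near that of compound 1, an estimated step of no change at the digits printed from compound 1 to compound 4 (within the scatter) that is within the scatter. Compound 4 is therefore estimated at 10000 nM, with a range from 3000 nM to 30000 nM.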

Compound 4, concentration for 50% growth inhibition: 10000 nM
Compound 4: middle estimate and measured number agree at the digits printed, within the range that was stated.
By their numbers in this assay, from the lowest: compounds 1, 2, 4 and 3 (each within the scatter of the next).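

Putting 4-bromo-3-nitrophenyl in place of 2-fluoro-4-methoxyphenyl on a double-bonded chain carbon bound to a double-bonded chain carbon gives, in this assay, no change at the digits printed from compound 1 to compound 4 (within the scatter). For the compounds shown here, this is the first view of this position, and it shows that two quite different sets of ring substituents, a fluoro with a methoxy and a bromo with a nitro, can sit here without separating the two compounds on this read-out. Nothing available here accounts for why the two groups read alike.

The compounds shown leave open whether any group at this position can move the number at all, for instance a plain phenyl ring, a ring carrying an amine or a carboxylic acid, or a longer alkyl chain in place of the ring. They also leave open whether 4-bromo-3-nitrophenyl would read the same when paired with the (4-bromophenyl)sulfanyl group of compound 3, since this change has been seen only alongside the (4-bromophenyl)sulfonyl group of compound 1.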